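From 4-fluorophenyl to 4-methoxyphenyl in the series

The source may hold more compounds than are shown below. What is called first, only, known or untested is meant among the compounds shown, and "the series" means these compounds.

Of the compounds shown here, two sharing the same core have been measured so far. Compound 1 (`CC(C)(NC(=O)c1cnc(-n2cccn2)nc1O)c1ccccc1`) gives > 100 h in an ADME assay on the whole organism (Canis lupus familiaris) for metabolic stability (on this read-out lower numbers stand for a shorter-lived compound and higher numbers for a longer-lived compound), and this value is a limit of the assay and not a number.

Among the compounds with values here, compound 2 (`C[C@H](NC(=O)c1cnc(-n2cccn2)nc1O)c1ccc(F)cc1`) gives 60 h in this assay, which makes it the only true number available. Its position therefore cannot be read against a second number.

Compound 3 (`COc1ccc([C@H](C)NC(=O)c2cnc(-n3cccn3)nc2O)cc1`) is compound 2 with methoxy in place of fluoro on an aromatic carbon, para to a large group (methoxy in place of fluoro on an aromatic carbon). The rest of the structure stays the same.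

Within the data shown here, no measured pair differs in one place only, so nothing yet sizes this change directly. The expectation rests on compound 2 at 60 h and on the structural change alone, and it carries a wide margin.

A modest move toward a shorter half-life is expected, and the expected step of a 1.7-fold lower number from compound 2 to compound 3 (0.23 log units; within the scatter) may not clear the usual scatter by much. For compound 3 the estimate is 35 h (expected range 12 h to 90 h).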

Compound 3, half-life: 94 h
For compound 3 the middle estimate is 2.7-fold (0.43 log units) below the measured one; the measured number lies above the stated range.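

Methoxy in place of fluoro on an aromatic carbon, para to a large group, now has a measured size in this assay: a 1.6-fold higher number from compound 2 to compound 3 (0.19 log units; within the scatter). Within the data shown here, this single pair gives the first direct reading at this position, and the read-out does not separate the 4-fluorophenyl and 4-methoxyphenyl compounds, so either group can stand here without a step that clears the scatter. Any group at this position that reads longer-lived than compound 3 could run into the ceiling already met by compound 1, whose value is a limit and not a number: the limit of > 100 h in this assay, at which 1 of the 3 values shown sits.

Still open, as far as these compounds go, is how this position responds to a group of a different kind, such as an amine, a carboxylic acid or a longer alkoxy chain in place of methoxy. Also open, from the compounds shown here alone, is whether the step seen in this one pair carries over to another species or to the side chain of compound 1, since a single pair within the scatter gives no trend for either.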